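A few compounds are considered here, and "the series" means these few. Any claim that something is new, unique, unknown or untested is made for them only; others in the source may bear on it.

Measured so far:
compound 1 `O=C(/C=C/c1ccc(/C=C/C(=O)c2ccc3ccccc3c2)o1)NO`, 29400 nM
compound 2 `O=C(/C=C/c1ccc(/C=C/C(=O)c2ccc(Cl)cc2)o1)NO`, 98100 nM

In a functional assay on A549 cells (Homo sapiens) for antiproliferative activity, read by MTT assay, with a stated time of 48 h (on this read-out lower numbers stand for stronger inhibition and higher numbers for weaker inhibition), compound 2 gives 98100 nM, the higher of the two numbers; compound 1 gives 29400 nM, lower by a gap beyond the scatter. Compound 3 `Cc1ccc(C(=O)/C=C/c2ccc(/C=C/C(=O)NO)o2)cc1` keeps the core of compound 2 and differs only by methyl in place of chloro on an aromatic carbon. Within the data shown here, no measured pair shows this change, so no direction is known from the numbers; a step from compound 2 to compound 3 of a 1.3-fold lower number from compound 2 to compound 3 (0.12 log units; within the scatter) is expected, meaning no change beyond the scatter. For compound 3 the estimated value in this assay is 75000 nM, within 25000 nM to 220000 nM.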

Compound 3, half-maximal inhibitory concentration: 48600 nM
Estimate against measurement, compound 3: 1.5-fold (0.19 log units) above; the measured number falls inside the stated range.
By their numbers in this assay, from the lowest: compounds 1 and 3 (each within the scatter of the next); then compound 2.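

In this assay, among these compounds, the change from 4-chlorophenyl to 4-methylphenyl gives a 2.0-fold lower number from compound 2 to compound 3 (0.31 log units; beyond the scatter) and provides the first direct reading at this position. A swap of one heavy atom on the aromatic carbon para to a large group is thus enough to shift the number modestly, with methyl giving the lower number in this single pair. Nothing at hand accounts for the shift. As far as these compounds go, whether an amine or a methoxy group at the same position would move the number further remains open. A single pair also leaves open whether the direction would hold for other groups there.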